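Piperazine series: stability step from compound 3 to compound 4

The compounds below may be only part of what the source reports. "The series", "measured", "known", "first", "only" and "open" are said of these compounds alone.

Measured so far:
compound 1 `COc1ccc(Nc2ncc3ccc(-c4ccccc4OC)n3n2)cc1` gives 0.117 h
compound 2 `COc1ccccc1-c1ccc2cnc(Nc3ccc(S(=O)(=O)N(C)C)cc3)nn12` gives 0.0833 h
compound 3 `COc1ccccc1-c1ccc2cnc(Nc3cccc(N4CCN(C)CC4)c3)nn12` gives 0.117 h

All three numbers come from an in vitro ADME assay on microsomes from liver (Rattus norvegicus, strain Sprague-Dawley) for metabolic stability, using NADPH, with a stated time of 10 min, tested at 0.5 uM; a higher number here means that the compound lasts longer, a lower number that the compound disappears faster. Compound 3 stands level with compound 1 at the digits read, the two of them together the highest of the three, and its gap to compound 2 is within the scatter, so no order can be drawn among the measured set.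

Compound 4 `COc1ccccc1-c1ccc2cnc(Nc3cccc(N4CCN(C[C@H](C)O)CC4)c3)nn12` is the next member. It differs from compound 3 by 1-hydroxyethyl in place of hydrogen on a saturated chain carbon bound to an amine nitrogen in a ring. For the measured compounds named here, none of the measured steps touches this part of the molecule; the one step available, a 1.4-fold lower number from compound 1 to compound 2 (0.15 log units; within the scatter), concerns the substituent on the aromatic amine and stays within the scatter. Going by the values given here, the series so far gives no example of a change that moves this assay beyond its scatter, and nothing in the numbers points to a direction for this change.

For compound 4 the expected step is therefore a 1.0-fold higher number from compound 3 to compound 4 (0.01 log units; within the scatter), no change beyond the scatter. The estimate for compound 4 in this assay is 0.12 h, with a range from 0.06 h to 0.25 h.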

Compound 4, half-life: 0.1 h
Compound 4: middle estimate off by 1.2-fold (0.08 log units), on the high side; measured number inside the range.
By their numbers in this assay, from the lowest: compounds 2, 4, 1 and 3 (each within the scatter of the next).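

For the compounds shown here, replacing 4-methylpiperazin-1-yl with 4-(2-hydroxypropyl)piperazin-1-yl gives the first reading at this position in this assay, with a 1.2-fold lower number from compound 3 to compound 4 (0.07 log units; within the scatter) as the step. Going by these compounds alone, on a saturated chain carbon bound to an amine nitrogen in a ring, 1-hydroxyethyl in place of hydrogen therefore leaves the half-life indistinguishable from that of compound 3, so this added group, with its one defined stereocentre, produces no step that this assay can resolve. No measurement shown bears on what lies behind this result.

From the compounds shown here alone, whether a carboxylic acid, a primary amine or a longer chain at the same place would shift the half-life beyond the scatter remains open. Also open, going by these compounds, is whether the opposite configuration at the stereocentre would read any differently from compound 4.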